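Aryl swap at the saturated ring carbon: compound 4

A few compounds are considered here, and "the series" means these few. Any claim that something is new, unique, unknown or untested is made for them only; others in the source may bear on it.

Three analogues sharing one core have been run in a functional assay on Ehrlich cells (Mus musculus) for cytotoxicity, tested at 10 ug/mL; a higher number here means a stronger effect of the compound at the concentration tested, a lower number a weaker effect. Compound 1 `COc1ccc(C2C(C#N)=C(N)N(c3cc(OC)c(OC)c(OC)c3)C3=C2C(=O)CC(C)(C)C3)cc1` gives 0%, compound 2 `COc1cc(N2C(N)=C(C#N)C(c3c(O)ccc4ccccc34)C3=C2CC(C)(C)CC3=O)cc(OC)c1OC` gives 2%, and compound 3 `COc1cc(N2C(N)=C(C#N)C(c3cccc([N+](=O)[O-])c3)C3=C2CC(C)(C)CC3=O)cc(OC)c1OC` gives 5%. Compound 2 stands second highest of the three numbers; its nearest neighbour is compound 1, with a number 2 percentage points higher from compound 1 to compound 2 (within the scatter), and its furthest is compound 3, with a number 3 percentage points higher from compound 2 to compound 3 (within the scatter). Compound 4 `COc1cc(N2C(N)=C(C#N)C(c3ccc(C)o3)C3=C2CC(C)(C)CC3=O)cc(OC)c1OC` differs from compound 2 by 5-methylfuran-2-yl in place of 2-hydroxynaphthalen-1-yl on a saturated ring carbon. All three measured steps change the group on this same saturated ring carbon, and all stay within the scatter: a number 2 percentage points higher from compound 1 to compound 2 (within the scatter), a number 5 percentage points higher from compound 1 to compound 3 (within the scatter), a number 3 percentage points higher from compound 2 to compound 3 (within the scatter). On that record no step beyond the scatter is expected in this assay, so the estimated change is a number 1 percentage points higher from compound 2 to compound 4 (within the scatter). Compound 4 is therefore expected to give 3%, within a range of 0% to 12%.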

Compound 4, a percentage reported as activity, at one concentration (the size of the read-out at that concentration, not a potency): 21%
The estimate for compound 4 lay 18 percentage points below the measured number; measured number outside the range, above it.
By their numbers in this assay, from the lowest: compounds 1, 2 and 3 (each within the scatter of the next); then compound 4.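

The saturated ring carbon is not silent in this assay: with 5-methylfuran-2-yl there, the read-out shows a number 19 percentage points higher from compound 2 to compound 4 (beyond the scatter) and a number 16 percentage points higher from compound 3 to compound 4 (beyond the scatter) and also a number 21 percentage points higher from compound 1 to compound 4 (beyond the scatter), all beyond the scatter. Among the four groups compared, only 5-methylfuran-2-yl is a five-membered aromatic ring with a hetero atom. Nothing available bears on the origin of these steps.

As far as these compounds go, whether the steps follow the furan ring or its methyl group stays open. Unsubstituted furan-2-yl and 5-methylthiophen-2-yl at this carbon would separate the two.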